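The compounds below may be only part of what the source reports. "The series", "measured", "known", "first", "only" and "open" are said of these compounds alone.

Measured compounds:

Compound 1 `CCCCC(CCO)n1cnc2c(Cl)ncnc21`: in a functional assay on SW480 cells (Homo sapiens) for antiproliferative activity, read by MTT assay, with a stated time of 48 h (on this read-out higher numbers stand for weaker inhibition and lower numbers for stronger inhibition), compound 1 sits at > 50000 nM, which is a limit of the assay and not a number.
Compound 2 `CCCCC(CCO)n1cnc2c(Cl)nc(Cl)nc21`: in this assay compound 2 gives 30900 nM.
Compound 3 `CCCCCCCC(CCO)n1cnc2c(N)ncnc21`: in this assay compound 3 sits at > 50000 nM, again a limit of the assay.

Going by the values given here, only one step between measured compounds is available. It runs an at least 1.6-fold lower number from compound 1 to compound 2 (0.20 log units; that floor lies within the scatter); the change is chloro in place of hydrogen on an aromatic carbon. Compound 4 `CCCCCCCC(CCO)n1cnc2c(N)nc(Cl)nc21` has not yet been measured. The difference between the core of compound 3 and the core of compound 1 is not broken down here. From compound 3 to compound 4 the change is chloro in place of hydrogen on an aromatic carbon, the same kind of change as from compound 1 to compound 2, though the surroundings of the place differ: here the entering group sits meta to an amino group, there meta to a chloro group. Two of the three values shown are the limit of > 50000 nM in this assay, at which 2 of the 3 values shown sit, so the series is thinly anchored. For compound 4 the step is expected to be an at least 1.4-fold lower number from compound 3 to compound 4 (0.15 log units; that floor lies within the scatter), resting on an at least 1.6-fold lower number from compound 1 to compound 2 (0.20 log units; that floor lies within the scatter) and on the limit at which compound 3 sits. Compound 4 is therefore estimated at 35000 nM, with a likely range from 12000 nM to 100000 nM.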

Compound 4, half-maximal inhibitory concentration: > 50000 nM
Compound 4 was reported as a limit; the forecaster's own chance of this, stated with the estimate: 45%; middle value at least 1.4-fold (0.15 log units) from the limit.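

Compound 3 and compound 4 both sit at a limit of the assay and not at a number, so no step between them can be read: the limit of > 50000 nM in this assay, at which 3 of the 4 values shown sit.

The compounds shown leave open whether chloro in place of hydrogen on an aromatic carbon changes the number in this assay on the core of compound 3 at all.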